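From a limit towards a number: compound 3

The compounds below may be only part of what the source reports. "The series", "measured", "known", "first", "only" and "open" are said of these compounds alone.

- compound 1 `COc1cc2ncnc(Nc3ccc(F)c(Cl)c3)c2cc1OCCn1ccnc1[N+](=O)[O-]` gives > 50000 nM (a limit of the assay, not a number)
- compound 2 `C#Cc1cccc(Nc2ncnc3cc(OC)c(OCCCCCCn4ccnc4[N+](=O)[O-])cc23)c1` gives 2930 nM

Both compounds were tested in a functional assay on HT-29 cells (Homo sapiens) for cytotoxicity, read by sulforhodamine B assay, with a stated time of 72 h; on this read-out higher numbers stand for weaker inhibition and lower numbers for stronger inhibition. Compound 1 has no number here, only a limit: the limit of > 50000 nM in this assay, at which 1 of the 2 values shown sits. Compound 2, by contrast, returns a number, 2930 nM.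

Compound 3 `COc1cc2ncnc(Nc3ccc(F)c(Cl)c3)c2cc1OCCCCn1c([N+](=O)[O-])cnc1C` has not yet been measured. It differs from compound 1 by 2-(2-methyl-5-nitro-1H-imidazol-1-yl)ethyl in place of 2-nitro-1H-imidazol-1-yl on a saturated chain carbon, two bonds along the chain from an oxygen on an aromatic ring, with 2-(2-methyl-5-nitro-1H-imidazol-1-yl)ethyl in place of 2-nitro-1H-imidazol-1-yl on a saturated chain carbon, two bonds along the chain from an oxygen on an aromatic ring.

Within the data shown here, no measured pair shows what such a change does, so only a modest expectation is possible. Among the measured compounds shown here, compound 2 at 2930 nM is the only number available, and it serves as a loose guide to where a readable value might lie. A step towards stronger inhibition in this assay is expected, though compound 3 may well stay at the limit. The expected move is an at least 2.5-fold lower number from compound 1 to compound 3 (0.39 log units; beyond the scatter). The estimated value for compound 3 is 20000 nM, with an expected range from 6000 nM to 50000 nM.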

Compound 3, half-maximal inhibitory concentration: 8210 nM
Estimate against measurement, compound 3: 2.4-fold (0.39 log units) above; low and high end bracket the measured number.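

In this assay, putting 2-(2-methyl-5-nitro-1H-imidazol-1-yl)ethyl in place of 2-nitro-1H-imidazol-1-yl on a saturated chain carbon, two bonds along the chain from an oxygen on an aromatic ring, gives an at least 6.0-fold lower number from compound 1 to compound 3 (0.78 log units; beyond the scatter), so a change at this place alone on the shared core is enough to turn a limit into a readable number. Among these compounds, the true size of this step stays unknown because compound 1 has only a limit and not a number: the limit of > 50000 nM in this assay, at which 1 of the 3 values shown sits. The single step also carries several differences at once, the added ethyl, the 2-methyl and the 5-nitro of the entering group against the 2-nitro of the leaving one, and the result does not assign the gain to any one of them.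

The compounds shown leave open which of these differences matters, for instance whether a 2-nitro-1H-imidazol-1-yl group on the same longer chain would match compound 3. They also leave open whether a nitro-substituted ring is needed at all at this place, or whether a simple amine or a carboxylic acid at the end of the chain would give a readable number too.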